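The compounds below may be only part of what the source reports. "The series", "measured", "known", "first", "only" and "open" are said of these compounds alone.

Of the compounds shown here, three sharing one core have been tested in a functional assay on B16-F10 cells (Mus musculus) for cytotoxicity, read by MTT assay, with a stated time of 48 h; a higher number here means a weaker inhibitor, a lower number a stronger inhibitor. Compound 1 `COc1ccc(CN(C(=O)Nc2ccc(C#N)cc2)n2cnnc2)cc1OC` gives only a limit, > 50000 nM. Compound 2 `COc1ccc(CN(C(=O)Nc2ccc(Cl)c(C(F)(F)F)c2)n2cnnc2)cc1OC` likewise gives only a limit, > 50000 nM. For the measured compounds named here, compound 3 `CCc1ccc(NC(=O)N(Cc2ccc(OC)c(OC)c2)n2cnnc2)cc1` is the one member of the set with a real number: in this assay compound 3 gives 22900 nM. Going by the values given here, the single measured step runs from compound 1 to compound 3 and shows an at least 2.1-fold lower number from compound 1 to compound 3 (0.33 log units; beyond the scatter), which is the only guide to how a change at this position moves the number.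

Compound 4 `COc1ccc(CN(C(=O)Nc2ccc(Cl)cc2)n2cnnc2)cc1OC` has not yet been measured. It differs from compound 3 in one place: chloro in place of ethyl on an aromatic carbon. Among the compounds with values here, no measured step compares chloro with ethyl directly, so the expectation rests on weaker ground. What is known is that the limit of > 50000 nM in this assay, at which 2 of the 3 values shown sit, holds two of the three compounds, and compound 2, which also carries a chloro on the same ring, sits at that limit. Compound 4 is therefore expected to land closer to that limit than compound 3 does, with a fair chance of giving only a limit itself. This corresponds to an expected 1.7-fold higher number from compound 3 to compound 4 (0.24 log units; within the scatter). In this assay compound 4 is estimated at 40000 nM, within a range from 15000 nM to 100000 nM.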

Compound 4, half-maximal inhibitory concentration: 42200 nM
Compound 4: the middle estimate sits 1.1-fold (0.02 log units) below what was measured; measured number inside the range.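

In this assay, replacing ethyl with chloro on the aromatic carbon gives a 1.8-fold higher number from compound 3 to compound 4 (0.27 log units; within the scatter), so this single change does not clearly separate the two compounds, and both give real numbers rather than limits. The comparisons with the two limit compounds add little: removing trifluoromethyl gives an at least 1.1-fold lower number from compound 2 to compound 4 (0.07 log units; that floor lies within the scatter), and chloro in place of cyano gives an at least 1.1-fold lower number from compound 1 to compound 4 (0.07 log units; that floor lies within the scatter), so neither change can be shown to move the number beyond ordinary assay variation. These two steps give only floors, not true sizes, since each starts from a limit rather than a measured number: the limit of > 50000 nM in this assay, at which 2 of the 4 values shown sit.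

The compounds shown leave open whether a different kind of group at this position on the aromatic ring, such as an amine, a carboxylic acid or a longer chain like butyl, would shift the number beyond the scatter. They also leave open how much the number depends on the rest of the molecule, for example if hydroxyl groups took the place of the methoxy groups.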